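Aryl replacement on the methoxyphenyl: microsomal stability notes

A few compounds are considered here, and "the series" means these few. Any claim that something is new, unique, unknown or untested is made for them only; others in the source may bear on it.

Compound 1 `COc1ccc(C2=Nc3c(C(C)(C)C)nn(CCCO)c3C(=O)NC2)cc1-c1cnn(C)c1` carries a 1-methyl-1H-pyrazol-4-yl group on the shared core; in an ADME assay on microsomes from liver (Homo sapiens) for metabolic stability (on this read-out higher numbers stand for a longer-lived compound and lower numbers for a shorter-lived compound), compound 1 gives 2 h. Compound 2 `COc1ccc(-c2cc(C3=Nc4c(C(C)(C)C)nn(CCCO)c4C(=O)NC3)ccc2OC)c(OC)c1` gives 2 h, and compound 3 `COc1ccccc1-c1cc(C2=Nc3c(C(C)(C)C)nn(CCCO)c3C(=O)NC2)ccc1OC` gives 1.37 h. Compound 1 thus sits level with compound 2, the two together the highest of the three numbers, with compound 3 the furthest away: no change at the digits printed from compound 1 to compound 2 (within the scatter), a 1.5-fold lower number from compound 1 to compound 3 (0.16 log units; within the scatter), and a 1.5-fold lower number from compound 2 to compound 3 (0.16 log units; within the scatter), all within the scatter. Compound 4 `COc1ccc(C2=Nc3c(C(C)(C)C)nn(CCCO)c3C(=O)NC2)cc1-c1ccccc1SC` differs from compound 1 by 2-(methylsulfanyl)phenyl in place of 1-methyl-1H-pyrazol-4-yl on an aromatic carbon. The two measured aryl replacements at this same position bear on the change directly, and both stayed within the scatter, so no step beyond the scatter is expected in this assay for compound 4. Compound 4 is estimated at 1.6 h with a range of 0.8 h to 3.2 h. The expected step is a 1.3-fold lower number from compound 1 to compound 4 (0.10 log units; within the scatter).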

Compound 4, half-life: 0.85 h
Compound 4: middle estimate off by 1.9-fold (0.27 log units), on the high side; the range from low to high includes it.
By their numbers in this assay, from the lowest: compounds 4, 3, 1 and 2 (each within the scatter of the next, the first and the last beyond it).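

Going by these compounds alone, at this position, a 2.4-fold lower number from compound 1 to compound 4 (0.37 log units; beyond the scatter) and a 2.4-fold lower number from compound 2 to compound 4 (0.37 log units; beyond the scatter) are the first steps in this assay to lie beyond the scatter, so an aryl replacement here can shift the number. With methylsulfanyl in place of methoxy, a 1.6-fold lower number from compound 3 to compound 4 (0.21 log units; within the scatter) stays within the scatter, which leaves compound 4 unseparated from compound 3. No measurement shown explains the steps. Open, going by these compounds, is whether methylsulfonyl or a morpholine in place of methylsulfanyl would give numbers level with compound 1 and compound 2.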